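Swapping Fluoro for Ethyl on a Different Ring

The source may report more compounds than this note shows. Statements on the series, on what has been measured and on what is new or still open speak of the compounds shown alone.

In an assay on CHO-TREX cells for antagonist activity at transient receptor potential cation channel subfamily A member 1 (Homo sapiens), read by FLIPR and calcium flux, with a stated time of 10 min (a lower number here means a stronger inhibitor, a higher number a weaker inhibitor), compound 1 `Fc1ccccc1-c1ccc2[nH]ncc2c1` gives 3950 nM. Compound 2 `CCc1ccccc1-c1ccc2[nH]ncc2c1` differs from compound 1 in one place, (ethyl in place of fluoro on an aromatic carbon), and in this assay compound 2 gives 584 nM. That single change produced a 6.8-fold lower number from compound 1 to compound 2 (0.83 log units; beyond the scatter).

Compound 3 `Fc1cc2[nH]ncc2cc1-c1ccccc1C(F)(F)F` rests on a different core; how the cores of compound 3 and compound 1 differ is not broken down here. In this assay, among the compounds with values here, compound 3 gives 48 nM, the lowest of the three numbers measured so far.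

Compound 4 `CCc1cc2[nH]ncc2cc1-c1ccccc1C(F)(F)F` has not yet been measured. It differs from compound 3 by ethyl in place of fluoro on an aromatic carbon. Within the data shown here, this is the same kind of change as the one from compound 1 to compound 2, but its surroundings are not the same: in compound 2 the ethyl sits on a six-membered aromatic ring of carbon only, ortho to a group of 9 heavy atoms, whereas in compound 4 it sits on a six-membered aromatic ring of carbon only that is part of a fused or bridged system of two rings, ortho to a large group, meta to a fused ring and para to a fused ring.

Among the measured compounds shown here, the change is expected to make a smaller step this time, namely a 1.6-fold lower number from compound 3 to compound 4 (0.20 log units; within the scatter), because the only measured precedent a 6.8-fold lower number from compound 1 to compound 2 (0.83 log units; beyond the scatter) was made on a different ring. Compound 4 is therefore expected to give 30 nM in this assay, with a plausible range from 8 nM to 150 nM.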

Compound 4, half-maximal inhibitory concentration: 50 nM
Estimate against measurement, compound 4: 1.7-fold (0.22 log units) below; the range from low to high includes it.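

In this assay, putting ethyl in place of fluoro on the core of compound 3 gives a 1.0-fold higher number from compound 3 to compound 4 (0.02 log units; within the scatter), so compound 3 and compound 4 cannot be told apart in this measurement. The swap therefore did not carry over at the same size from one core to the other, and the step measured on the core of compound 1 would have been a poor guide to the step on the core of compound 3: the same change on two cores in this assay, a 6.8-fold lower number (0.83 log units; beyond the scatter) from compound 1 to compound 2 and a 1.0-fold higher number (0.02 log units; within the scatter) from compound 3 to compound 4, 7.0-fold (0.85 log units) apart, beyond the scatter of two such steps

Within the data shown here, this comparison rests on only one pair of compounds on each core, and it does not show why the two steps differ, since the two pairs differ both in their cores and in the ring that carries the swap, and these four compounds cannot separate those two factors. The compounds shown leave open whether a different group at this position on the core of compound 3, such as a longer propyl chain or an amine, would move the number beyond the scatter. They also leave open whether the swap on a third core would resemble the step seen on the core of compound 1 or the one seen on the core of compound 3.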